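Pyridin-4-yl for 4-chlorophenyl: cytotoxicity expected to stay low

A few compounds are considered here, and "the series" means these few. Any claim that something is new, unique, unknown or untested is made for them only; others in the source may bear on it.

Compound 1 `COc1nc(-c2ccc(Cl)cc2)ccc1[C@@H](c1ccccc1)[C@@](O)(CCN(C)C)c1cccc2ccccc12`: in a toxicity assay on HeLa cells (Homo sapiens) for cytotoxicity (on this read-out higher numbers stand for lower toxicity in this test and lower numbers for higher toxicity in this test), compound 1 gives > 64 ug/mL, which is a limit of the assay and not a number.
Compound 2 `COc1nc(-c2ccc(F)cc2)ccc1[C@@H](c1ccccc1)[C@@](O)(CCN(C)C)c1cccc2ccccc12`: in this assay compound 2 gives > 64 ug/mL, again a limit and not a number.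
Compound 3 `COc1nc(-c2ccsc2)ccc1[C@@H](c1ccccc1)[C@@](O)(CCN(C)C)c1cccc2ccccc12`: in this assay compound 3 gives > 64 ug/mL, also a limit and not a number.

Compound 1 therefore stands only at a limit in this assay, and the other two values are limits as well (the limit of > 64 ug/mL in this assay, at which 3 of the 3 values shown sit). The measured steps that bear on the change, a step that the two limits leave unreadable from compound 1 to compound 2 and a step that the two limits leave unreadable from compound 1 to compound 3, cannot be sized, since both ends sit at the limit; the same holds for a step that the two limits leave unreadable from compound 2 to compound 3.

Compound 4 `COc1nc(-c2ccncc2)ccc1[C@@H](c1ccccc1)[C@@](O)(CCN(C)C)c1cccc2ccccc12` differs from compound 1 in one place: pyridin-4-yl in place of 4-chlorophenyl on an aromatic carbon. Three different groups at this position have all left the value at the limit, so no step beyond the scatter is expected in this assay, and compound 4 will most likely also be reported only as a limit. The step from this reasoning is expected to be a step that the limit leaves unreadable from compound 1 to compound 4. Compound 4 is estimated at 80 ug/mL, within a range of 35 ug/mL to 200 ug/mL.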

Compound 4, half-maximal cytotoxic concentration: 9.6 ug/mL
Estimate against measurement, compound 4: 8.3-fold (0.92 log units) above, outside the stated range (below it).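

The three groups at the limit made this position look as if it had no bearing on toxicity in this assay, but pyridin-4-yl shows that the group placed here can matter. Lower numbers mean higher toxicity in this test, and the change gives an at least 6.6-fold lower number from compound 1 to compound 4 (0.82 log units; beyond the scatter), along with an at least 6.6-fold lower number from compound 2 to compound 4 (0.82 log units; beyond the scatter) and an at least 6.6-fold lower number from compound 3 to compound 4 (0.82 log units; beyond the scatter), so a swap at this one position moves the read-out beyond the scatter. The steps among compounds 1, 2 and 3 cannot be read, and the three new steps give only minimum sizes, because their starting values are limits: the limit of > 64 ug/mL in this assay, at which 3 of the 4 values shown sit.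

On these data alone, the full size of the change therefore stays unknown. As far as these compounds go, it also stays open whether the ring nitrogen or its place in the ring drives the change, which pyridin-3-yl or 4-aminophenyl at this position could help to separate.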